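A few compounds are considered here, and "the series" means these few. Any claim that something is new, unique, unknown or untested is made for them only; others in the source may bear on it.

Among the compounds with values here, in a functional assay on Ehrlich cells (Mus musculus) for cytotoxicity, read by trypan blue exclusion, with a stated time of 2 h (a higher number here means a weaker inhibitor, a lower number a stronger inhibitor), compound 1 `N#CC1=C(N)N(c2ccc(S(N)(=O)=O)cc2)C2=C(CCCC2)C1c1ccccc1O` gives 118000 nM and compound 2 `N#CC1=C(N)N(c2ccc(S(N)(=O)=O)cc2)C2=C(CCCC2)C1c1ccc(O)cc1` gives 82900 nM, so the only two measured compounds lie within the scatter of each other. Compound 3 `COc1ccc(C2C(C#N)=C(N)N(c3ccc(S(N)(=O)=O)cc3)C3=C2CCCC3)cc1` differs from compound 1 by one change, 4-methoxyphenyl in place of 2-hydroxyphenyl on a saturated ring carbon. Within the data shown here, the one measured step that bears on this replaces the same 2-hydroxyphenyl with 4-hydroxyphenyl, giving a 1.4-fold lower number from compound 1 to compound 2 (0.15 log units; within the scatter). No change beyond the scatter is therefore expected in this assay. The expected size is a 1.2-fold lower number from compound 1 to compound 3 (0.09 log units; within the scatter). For compound 3 the estimated value is 95000 nM, with an expected range of 40000 nM to 220000 nM.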

Compound 3, half-maximal inhibitory concentration: 22900 nM
Beside the measured number, compound 3's estimate is 4.1-fold (0.62 log units) above it; measured number outside the range, below it.
By their numbers in this assay, from the lowest: compound 3; then compounds 2 and 1 (each within the scatter of the next).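

In this assay, the group on this saturated ring carbon can move the number beyond the scatter, which the two hydroxyphenyl compounds did not show. Methyl on the oxygen of the 4-hydroxyphenyl group gives a 3.6-fold lower number from compound 2 to compound 3 (0.56 log units; beyond the scatter) and removes the hydrogen-bond donor, while the full replacement of 2-hydroxyphenyl gives a 5.2-fold lower number from compound 1 to compound 3 (0.71 log units; beyond the scatter) in the same direction. Nothing available explains why this step counts.

Still open, as far as these compounds go, is whether a 2-methoxyphenyl group would match compound 3. A 4-ethoxyphenyl group or a 4-aminophenyl group could also show whether the methyl itself matters.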